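This account rests on a few compounds, and the source may have more. Where it says the series, first, only, none or still open, it means among the compounds named here.

Working notes on a short rhodanine series tested in a functional assay on HeLa cells (Homo sapiens) for cytotoxicity, read by MTT assay, with a stated time of 48 h; a higher number here means a weaker inhibitor, a lower number a stronger inhibitor.

Compound 1 `Cc1ccc(Cn2c(/C=C3\SC(=S)N(CC(=O)O)C3=O)nc3ccc(Cl)cc32)cc1` gives 11000 nM in this assay. Compound 2 `Cc1ccc(Cn2c(/C=C3\SC(=S)N(CC(=O)O)C3=O)nc3ccc(F)cc32)cc1` gives 3920 nM in this assay. Compound 3 `O=C(O)CN1C(=O)/C(=C/c2nc3cc(Cl)ccc3n2Cc2ccccc2F)SC1=S` gives 9520 nM in this assay; its number and that of compound 1 lie within the scatter of each other. Compound 4 `O=C(O)CN1C(=O)/C(=C/c2nc3cc(F)ccc3n2Cc2ccccc2F)SC1=S` is not yet measured. How the core of compound 3 differs from the core of compound 1 is not broken down here.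

One change recurs twice in the set. From compound 1 to compound 2 it is fluoro in place of chloro on an aromatic carbon, and it made a 2.8-fold lower number from compound 1 to compound 2 (0.45 log units; beyond the scatter). From compound 3 to compound 4 the change is fluoro in place of chloro on an aromatic carbon, the same change at the same place. Going by the values given here, only this single prior instance is available, so the expectation rests on it alone.

Compound 4 is expected to show a 2.6-fold lower number from compound 3 to compound 4 (0.42 log units; beyond the scatter) in this assay, a step of about the size seen before, because a 2.8-fold lower number from compound 1 to compound 2 (0.45 log units; beyond the scatter) was measured for the same change. Compound 4 is thus estimated at 3600 nM in this assay, with a likely range from 1500 nM to 8500 nM.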

Compound 4, half-maximal inhibitory concentration: > 50000 nM
Compound 4 ended at the assay's limit (the forecaster's own chance of this, stated with the estimate: 5%); middle value at least 13-fold (1.14 log units) away from the limit.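

In this assay fluoro in place of chloro on an aromatic carbon gave an at least 5.2-fold higher number from compound 3 to compound 4 (0.72 log units; beyond the scatter), so the step seen on the core of compound 1 does not carry over to the core of compound 3: the same change on two cores in this assay, a 2.8-fold lower number (0.45 log units; beyond the scatter) from compound 1 to compound 2 and an at least 5.2-fold higher number (0.72 log units; beyond the scatter) from compound 3 to compound 4, at least 14-fold (1.16 log units) apart, beyond the scatter of two such steps

Compound 4 stands at a limit of the assay, not at a number: the limit of > 50000 nM in this assay, at which 1 of the 4 values shown sits.

On these data alone, the full size of the step from the chloro to the fluoro compound on this second core stays unknown, and two pairs show only that the outcome of this change differs with the core, not which difference between the two cores matters.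

The compounds shown leave open whether bromo, methoxy or an amine at the same place would follow the pattern of the core of compound 1 or that of the core of compound 3. As far as these compounds go, all four compounds carry the carboxylic acid, so the behaviour of an ester or an amide in its place also remains open.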